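The source may report more compounds than this note shows. Statements on the series, on what has been measured and on what is new or still open speak of the compounds shown alone.

Measured compounds in an ADME assay on A549 cells (Homo sapiens) for cytotoxicity, read by MTT assay, with a stated time of 48 h; a higher number here means a weaker inhibitor of growth, a lower number a stronger inhibitor of growth:
Compound 1 `O=C(/C=C\c1ccccc1)N1N=C(c2ccncc2)OC1c1c[nH]c2ccccc12` gives > 30 ug/mL, a limit of the assay.
Compound 2 `O=C(/C=C\c1ccccc1O)N1N=C(c2ccncc2)OC1c1c[nH]c2ccccc12` gives > 30 ug/mL, a limit of the assay.
Compound 3 `Cc1ccc(/C=C\C(=O)N2N=C(c3ccncc3)OC2c2c[nH]c3ccccc23)cc1` gives > 30 ug/mL, also a limit of the assay.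

Compound 3 thus stands only at a limit in this assay, and the two other values shown are limits as well (the limit of > 30 ug/mL in this assay, at which 3 of the 3 values shown sit). Compound 4 `O=C(/C=C\c1ccc(Br)cc1)N1N=C(c2ccncc2)OC1c1c[nH]c2ccccc12` differs from compound 3 by bromo in place of methyl on an aromatic carbon. The measured steps a step that the two limits leave unreadable from compound 1 to compound 2, a step that the two limits leave unreadable from compound 1 to compound 3 and a step that the two limits leave unreadable from compound 2 to compound 3 all run between limits, and none gives a readable size. None involves a bromo group either. Nothing in these data points to a step beyond the scatter in this assay. Compound 4 is expected to sit at the same limit, a step that the limit leaves unreadable from compound 3 to compound 4. The estimate for compound 4 is 40 ug/mL, with a range from 20 ug/mL to 100 ug/mL.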

Compound 4, concentration for 50% growth inhibition: > 30 ug/mL
Compound 4 ended at the assay's limit; the forecaster's own chance of this, stated with the estimate: 70%; the middle value is on the limit's open side.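

The steps from compound 1, compound 2 and compound 3 to compound 4 cannot be read, since all four compounds sit at one limit: the limit of > 30 ug/mL in this assay, at which 4 of the 4 values shown sit.

Left open is how far apart these four compounds really lie in this assay.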